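This account rests on a few compounds, and the source may have more. Where it says the series, first, only, none or still open, it means among the compounds named here.

Measured compounds:
compound 1, `NS(=O)(=O)c1ccc(C(=O)NNC(=O)c2ccc(F)cc2)cc1`, in an assay on cells for inhibition of Amine oxidase [flavin-containing] A (Homo sapiens), read by fluorescence and spectrophotometry, using microsomes, with a stated time of 20 min (a lower number here means a stronger inhibitor, a higher number a weaker inhibitor), gives 39600 nM;
compound 2, `NS(=O)(=O)c1ccc(-c2nnc(-c3ccc(Cl)cc3)o2)cc1`, gives 68000 nM;
compound 3, `NS(=O)(=O)c1ccc(-c2nnc(-c3ccc(F)cc3)o2)cc1`, gives 83800 nM.

Compounds 2 and 3 share one core, and the change between them is chloro in place of fluoro on an aromatic carbon. This gave a 1.2-fold lower number from compound 3 to compound 2 (0.09 log units; within the scatter). The difference between the core of compound 3 and the core of compound 1 is not broken down here; compound 1 gives the lowest of the three numbers, though compound 2 stands within the scatter of it.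

Compound 4, `NS(=O)(=O)c1ccc(C(=O)NNC(=O)c2ccc(Cl)cc2)cc1`, has not been measured in this assay. It differs from compound 1 by chloro in place of fluoro on an aromatic carbon, the same change seen from compound 3 to compound 2. Because that change gave a 1.2-fold lower number from compound 3 to compound 2 (0.09 log units; within the scatter), the expected step is a 1.2-fold lower number from compound 1 to compound 4 (0.08 log units; within the scatter). Compound 4 is estimated at 33000 nM, with a range from 15000 nM to 75000 nM.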

Compound 4, half-maximal inhibitory concentration: 55900 nM
For compound 4 the middle estimate is 1.7-fold (0.23 log units) below the measured one; the measured number falls inside the stated range.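

In this assay, chloro in place of fluoro on the core of compound 1 gave a 1.4-fold higher number from compound 1 to compound 4 (0.15 log units; within the scatter), a step within the scatter. Set beside the earlier step on the other core, it does not differ from it by more than the scatter allows: the same change on two cores in this assay, a 1.2-fold lower number (0.09 log units; within the scatter) from compound 3 to compound 2 and a 1.4-fold higher number (0.15 log units; within the scatter) from compound 1 to compound 4, 1.7-fold (0.24 log units) apart, within the scatter of two such steps. This shows that the change behaved alike on both cores, in that neither step separates chloro from fluoro, but it does not show a true opposite direction on the two cores or any real effect of the change.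

The compounds shown leave open whether a different group at that place, such as an amine, a methoxy group or a carboxylic acid, would stand apart from these halogens. They also leave open whether bromo would follow chloro and fluoro on either core.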